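The compounds below may be only part of what the source reports. "The series", "measured", "known", "first", "only" and "open" are said of these compounds alone.

Of the compounds shown here, three that share one core have been measured in a functional assay on BXPC-3 cells (Homo sapiens) for inhibition, read by MTT assay, with a stated time of 72 h; on this read-out lower numbers stand for stronger inhibition of growth and higher numbers for weaker inhibition of growth. Compound 2 `O=S(=O)(NCCCNCc1ccc(Cl)cc1)c1cc(C(F)(F)F)cc(C(F)(F)F)c1` gives 1600 nM in this assay, the lowest of the three numbers. Compound 3 `O=S(=O)(NCCCNCc1ccc(C(F)(F)F)cc1)c1cc(C(F)(F)F)cc(C(F)(F)F)c1` gives 1700 nM, and the step of a 1.1-fold higher number from compound 2 to compound 3 (0.03 log units; within the scatter) leaves these two compounds indistinguishable. Compound 1 `CC(C)(C)c1ccc(CNCCNS(=O)(=O)c2cc(C(F)(F)F)cc(C(F)(F)F)c2)cc1` gives 8800 nM, a distinctly higher number than compound 2, but compound 1 differs from compound 2 in more than one place, so its value shows only where it lands and not what any single change does.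

Compound 4 `O=S(=O)(NCCCNCC1COc2ccccc2O1)c1cc(C(F)(F)F)cc(C(F)(F)F)c1` has not yet been measured. It is built from compound 2 by the change (2,3-dihydro-1,4-benzodioxin-2-yl in place of 4-chlorophenyl on a saturated chain carbon bound to an amine nitrogen). Among the compounds with values here, only one measured step, a 1.1-fold higher number from compound 2 to compound 3 (0.03 log units; within the scatter), touches this end of the molecule, and it exchanged one small group for another while the aromatic ring itself stayed in place. Within the data shown here, the change to compound 4 removes that ring and brings in a larger two-ring group carrying two hydrogen-bond acceptors, something no measured pair tests. The expectation is therefore a step of a 1.9-fold higher number from compound 2 to compound 4 (0.27 log units; within the scatter), leaning toward a higher number, with wide uncertainty. Compound 4 is estimated at 3000 nM, within a range from 1000 nM to 12000 nM.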

Compound 4, concentration for 50% growth inhibition: 1200 nM
Estimate against measurement, compound 4: 2.5-fold (0.40 log units) above, within the range that was stated.
By their numbers in this assay, from the lowest: compounds 4, 2 and 3 (each within the scatter of the next); then compound 1.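

In this assay, putting 2,3-dihydro-1,4-benzodioxin-2-yl in place of 4-chlorophenyl gives a 1.3-fold lower number from compound 2 to compound 4 (0.12 log units; within the scatter), and putting it in place of 4-(trifluoromethyl)phenyl gives a 1.4-fold lower number from compound 3 to compound 4 (0.15 log units; within the scatter). Within the data shown here, the only earlier comparison at this end of the molecule changed a small group while keeping the aromatic ring in place, whereas these two steps replace the whole substituted phenyl group with a larger two-ring group carrying hydrogen-bond acceptors, and neither step moves the number beyond the usual scatter. No measurement is available that accounts for this result.

The compounds shown leave open which part of the new group matters, and a 1,2,3,4-tetrahydronaphthalen-2-yl group, which has carbon where 2,3-dihydro-1,4-benzodioxin-2-yl has its ring oxygens, would test the oxygens directly. They also leave open how far this position can be changed before the number moves clearly, for example with a cyclohexyl group, which has no aromatic ring, or with a pyridine ring, which has a ring nitrogen.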